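Swapping Chloro for Methoxy in a Cytotoxicity Test

The compounds below may be only part of what the source reports. "The series", "measured", "known", "first", "only" and "open" are said of these compounds alone.

In an ADME assay on HEK293 cells (Homo sapiens) for cytotoxicity, read by MTT assay, with a stated time of 72 h (on this read-out higher numbers stand for weaker inhibition and lower numbers for stronger inhibition), compound 1 `COc1ccc(C(=O)N2CCN(CC(=O)N3CCN(CCCc4c[nH]c5ccc(F)cc45)CC3)CC2)cc1` gives 141000 nM. Compound 2 `COc1ccc2[nH]cc(CCCN3CCN(C(=O)CN4CCN(C(=O)c5ccc(Cl)cc5)CC4)CC3)c2c1` gives 117000 nM, which places it within the usual scatter of compound 1. Compound 3 `COc1ccc(C(=O)N2CCN(CC(=O)N3CCN(CCCc4c[nH]c5ccc(OC)cc45)CC3)CC2)cc1` has not yet been measured. Its structure has methoxy in place of chloro on an aromatic carbon, para to a large group, compared with compound 2: methoxy in place of chloro on an aromatic carbon. For the measured compounds named here, no measured pair shows this single change, so no shift beyond the scatter is expected, an estimated 1.1-fold higher number from compound 2 to compound 3 (0.05 log units; within the scatter). Compound 3 is expected at 130000 nM, with an estimated range from 60000 nM to 280000 nM.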

Compound 3, half-maximal inhibitory concentration: 190000 nM
Estimate against measurement, compound 3: 1.5-fold (0.16 log units) below; low and high end bracket the measured number.
By their numbers in this assay, from the lowest: compounds 2, 1 and 3 (each within the scatter of the next).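

In this assay, methoxy in place of chloro gives a 1.6-fold higher number from compound 2 to compound 3 (0.21 log units; within the scatter) and methoxy in place of fluoro gives a 1.3-fold higher number from compound 1 to compound 3 (0.13 log units; within the scatter) on an aromatic carbon. For the compounds shown here, this is the first direct reading of these changes, and neither step can be told apart from ordinary repeat variation, so the aromatic carbon carrying chloro, para to a large group, accepts methoxy here with no clear shift in the number. No measurement shown here accounts for this result. Going by these compounds, whether an amine or a carboxylic acid on the same carbon would shift the number beyond the scatter stays open.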